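A few compounds are considered here, and "the series" means these few. Any claim that something is new, unique, unknown or untested is made for them only; others in the source may bear on it.

Measured so far:
Compound 1 `O=C(CCCCC1CCSS1)Nc1ccccc1Cl` gives "not active" (no number reported)
Compound 2 `O=C(CCCCC1CCSS1)Nc1ccc(Br)cn1` gives 32.1%
Compound 3 `O=C(CCCCC(S)CCS)Nc1cccc(Cl)c1` gives "not active" (no number reported)

In a functional assay on HO8910 cells (Homo sapiens) for inhibition, read by MTT assay, with a stated time of 24 h, tested at 100 ug/mL (on this read-out higher numbers stand for more inhibition of growth at the one concentration tested and lower numbers for less inhibition of growth), compound 3 gives "not active" (no number reported) and so has no single number, a result it shares with compound 1, while compound 2 alone carries a number. The next compound to be tested is compound 4 `Cc1cccc(NC(=O)CCCCC(S)CCS)c1` and it differs by one small swap. The change methyl in place of chloro on an aromatic carbon puts methyl in place of chloro on an aromatic carbon. For the measured compounds named here, no measured pair shows this swap, so the data give no size for it, and no step beyond the usual scatter is expected in this assay in either direction. Compound 4 is estimated at 10% with 0% to 30% as the expected range.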

Compound 4, percent growth inhibition at one concentration: "not active" (no number reported)
The entry for compound 4 holds no number; the estimate stays without a comparison.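

Compound 3 and compound 4 both read as not active without a number, so no step can be read between them, and no evidence bears on this result. As far as these compounds go, whether methyl in place of chloro changes growth inhibition stays open.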